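The compounds below may be only part of what the source reports. "The series", "measured", "known", "first", "only" and "open" are said of these compounds alone.

Compound 1 `CCCCC(C)n1ccc2cc(/C(C)=C/C(=O)Nc3ccccc3OCCCC(=O)O)ccc21`: 6 nM
Compound 2 `CCCCc1ccc(Cn2ccc3cc(/C(C)=C/C(=O)Nc4ccccc4OCCCC(=O)O)ccc32)cc1`: 100 nM
Compound 3 `C/C(=C\C(=O)Nc1ccccc1OCCCC(=O)O)c1ccc2c(ccn2C(c2ccccc2)C(C)C)c1`: 25 nM

In an assay on Prostate gland for inhibition of steroid 5-alpha-reductase (Rattus norvegicus) (a higher number here means a weaker inhibitor, a lower number a stronger inhibitor), compound 3 stands second highest of the three: its nearest neighbour is compound 2, with a 4.0-fold lower number from compound 2 to compound 3 (0.60 log units; beyond the scatter), and its furthest is compound 1, with a 4.2-fold higher number from compound 1 to compound 3 (0.62 log units; beyond the scatter). Compound 4 `C/C(=C\C(=O)Nc1ccccc1OCCCC(=O)O)c1ccc2c(ccn2C(CC(C)C)c2ccccc2)c1` is compound 3 with isobutyl in place of isopropyl on a saturated chain carbon bound to an aromatic carbon and an aromatic nitrogen. All three measured steps exchange the whole group on the aromatic nitrogen, and they show that this group matters, as a 17-fold higher number from compound 1 to compound 2 (1.22 log units; beyond the scatter) makes clear. None of them tests merely lengthening a branch of that group from isopropyl to isobutyl, so the closest guide is that such changes have moved this assay by modest to large amounts. A small change is expected here, no change at the digits printed from compound 3 to compound 4 (within the scatter), within the scatter. Compound 4 is thus estimated at 25 nM, ranging from 8 nM to 80 nM.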

Compound 4, half-maximal inhibitory concentration: 6.3 nM
Estimate against measurement, compound 4: 4.0-fold (0.60 log units) above; the whole stated range lies above it.
By their numbers in this assay, from the lowest: compounds 1 and 4 (each within the scatter of the next); then compound 3; then compound 2.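

Lengthening the branch alone matters in this assay: isobutyl in place of isopropyl gives a 4.0-fold lower number from compound 3 to compound 4 (0.60 log units; beyond the scatter) with the rest of the molecule unchanged. The resulting 3-methyl-1-phenylbutyl group gives a 1.1-fold higher number from compound 1 to compound 4 (0.02 log units; within the scatter) against 1-methylpentyl and a 16-fold lower number from compound 2 to compound 4 (1.20 log units; beyond the scatter) against 4-butylbenzyl, so a group carrying a phenyl ring can match the open-chain one. Nothing measured here gives a reason for this shift.

On these data alone, whether a still longer chain, such as isopentyl, would lower the number further stays open. So does the effect of an amine at the end of that branch.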